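Second sulfonamide on the fused ring of the core

This account rests on a few compounds, and the source may have more. Where it says the series, first, only, none or still open, it means among the compounds named here.

The three measured compounds share one core and differ only in the group on the sulfonyl sulfur. Compound 1 `O=S(=O)(Nc1ccc(-c2nc3ccccc3o2)cc1)c1cccs1` gives 63000 nM in an assay on cells for inhibition of HSP60/HSP10 (Homo sapiens), with a stated time of 60 min; a higher number here means a weaker inhibitor, a lower number a stronger inhibitor. Compound 3 `O=S(=O)(Nc1ccc(-c2nc3ccccc3o2)cc1)c1ccc(Cl)s1` gives 31000 nM. Compound 2 `COc1ccc(S(=O)(=O)Nc2ccc(-c3nc4ccccc4o3)cc2)cc1` reaches only the limit > 100000 nM, which is a limit of the assay and not a number (the limit of > 100000 nM in this assay, at which 1 of the 3 values shown sits). Of the two numbers shown, compound 1 stands as the higher one; the step of a 2.0-fold lower number from compound 1 to compound 3 (0.31 log units; beyond the scatter) is modest, and the step of an at least 1.5-fold higher number from compound 1 to compound 2 (0.20 log units; that floor lies within the scatter) has its floor within the scatter.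

Compound 4 `O=S(=O)(Nc1ccc(-c2nc3cc(NS(=O)(=O)c4cccs4)ccc3o2)cc1)c1cccs1` is the next candidate. Against compound 1 the change is ((thiophen-2-yl)sulfonyl)amino in place of hydrogen on an aromatic carbon. Among the compounds with values here, none of the measured steps touches this place: all of them exchange the group on the sulfonyl sulfur, while the new group enters on the fused ring of the shared core, meta to a fused ring and para to a fused ring. Within the data shown here, no measured step therefore bears directly on this change, and no direction beyond the scatter can be drawn from them. The working expectation for compound 4 is a number close to that of compound 1, estimated as a 1.1-fold lower number from compound 1 to compound 4 (0.02 log units; within the scatter). Compound 4 is estimated at 60000 nM, in the range 20000 nM to 150000 nM.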

Compound 4, half-maximal inhibitory concentration: 40000 nM
The estimate for compound 4 lay 1.5-fold (0.18 log units) above the measured number; measured number inside the range.
By their numbers in this assay, from the lowest: compounds 3, 4 and 1 (each within the scatter of the next, the first and the last beyond it). At a limit, above all of these: compound 2.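

In this assay, ((thiophen-2-yl)sulfonyl)amino in place of hydrogen on the fused ring of the shared core gives a 1.6-fold lower number from compound 1 to compound 4 (0.20 log units; within the scatter), so this change leaves the number of compound 1 unmoved beyond the scatter. This is the only change shown away from the sulfonyl sulfur, and it indicates that this position, meta to a fused ring and para to a fused ring, can carry a second sulfonamide without a loss beyond the scatter, although no gain beyond the scatter is shown either. Nothing at hand accounts for this outcome at the new position.

As far as these compounds go, a single group at this position cannot show whether the position matters at all, so it remains open whether a small group such as an amine, an acetamide or a methoxy there would shift the number beyond the scatter. From the compounds shown here alone, it is also open whether chloro on the thiophene ring, which lowers the number on the sulfonyl side, would carry over to a compound with 5-chlorothiophen-2-yl on both sulfonyl groups.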